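This account rests on a few compounds, and the source may have more. Where it says the series, first, only, none or still open, it means among the compounds named here.

In a functional assay on A549 cells (Homo sapiens) for antiproliferative activity, read by MTT assay, with a stated time of 72 h (on this read-out lower numbers stand for stronger inhibition and higher numbers for weaker inhibition), three compounds have been measured so far: compound 1 `NC1=NC2(CCOCC2)N(OCCCOc2ccc(Cl)cc2Cl)C(N)=N1` (at 70 nM), compound 2 `NC1=NC2(CCOCC2)N(OCCCOc2cccc(Br)c2)C(N)=N1` (at 160 nM) and compound 3 `NC1=NC2(CCOCC2)N(OCCCOc2cccc(Cl)c2)C(N)=N1` (at 150 nM). That last number has one close neighbour (a 1.1-fold lower number from compound 2 to compound 3 (0.03 log units; within the scatter)) and one more distant neighbour (a 2.1-fold higher number from compound 1 to compound 3 (0.33 log units; beyond the scatter)). Compound 4 `NC1=NC2(CCOCC2)N(OCCCOc2ccc(Br)cc2)C(N)=N1` has 4-bromophenyl in place of 3-chlorophenyl on an oxygen on a saturated carbon. Exchanging bromo for chloro stayed within the scatter (a 1.1-fold lower number from compound 2 to compound 3 (0.03 log units; within the scatter)), and the larger ring changes were modest (a 2.3-fold higher number from compound 1 to compound 2 (0.36 log units; beyond the scatter) and a 2.1-fold higher number from compound 1 to compound 3 (0.33 log units; beyond the scatter)). Within the data shown here, no measured compound carries 4-bromophenyl itself. In this assay only a small step toward a slightly lower number is therefore expected (a 1.3-fold lower number from compound 3 to compound 4 (0.10 log units; within the scatter)) and it may well stay within the scatter. The estimated value for compound 4 is 120 nM with an expected range from 55 nM to 270 nM overall.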

Compound 4, half-maximal inhibitory concentration: 280 nM
For compound 4 the middle estimate is 2.3-fold (0.37 log units) below the measured one; measured number outside the range, above it.
By their numbers in this assay, from the lowest: compound 1; then compounds 3, 2 and 4 (each within the scatter of the next).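

In this assay, moving the bromine around the phenyl ring gives a 1.8-fold higher number from compound 2 to compound 4 (0.24 log units; within the scatter), and changing both halogen and place gives a 1.9-fold higher number from compound 3 to compound 4 (0.27 log units; within the scatter), so neither step shows that a single halogen's place matters. Replacing 2,4-dichlorophenyl gives a 4.0-fold higher number from compound 1 to compound 4 (0.60 log units; beyond the scatter), leaving compound 1 with the lowest number, beyond the scatter from all three compounds carrying one halogen. Nothing available explains this separation. The compounds shown leave open how an unsubstituted phenyl, a methoxy group on the ring or a longer chain before the phenoxy group would behave.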